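The compounds below may be only part of what the source reports. "The series", "measured", "known", "first", "only" and "open" are said of these compounds alone.

Compound 1 `Brc1ccc2[nH]c(-c3cncn3Cc3ccccc3)cc2c1` in an assay on isolated protein for inhibition of Indoleamine 2,3-dioxygenase 1 (Homo sapiens), with a stated time of 1 h (on this read-out higher numbers stand for weaker inhibition and lower numbers for stronger inhibition), gives 13600 nM. Compound 2 `Brc1ccc2[nH]c(-c3cncn3Cc3ccc(-c4ccccc4)cc3)cc2c1` gives 34200 nM in this assay, and a 2.5-fold higher number from compound 1 to compound 2 (0.40 log units; beyond the scatter). Compound 3 `FC(F)(F)c1ccc(Cn2cncc2-c2cc3cc(Br)ccc3[nH]2)cc1` reaches only the limit of > 100000 nM in this assay, which is the limit of > 100000 nM in this assay, at which 1 of the 3 values shown sits. Compound 3 is the weakest of the three measured compounds, since an at least 7.3-fold higher number from compound 1 to compound 3 (0.86 log units; beyond the scatter) and an at least 2.9-fold higher number from compound 2 to compound 3 (0.46 log units; beyond the scatter). Compound 4 `N#Cc1ccc(Cn2cncc2-c2cc3cc(Br)ccc3[nH]2)cc1` differs from compound 3 by cyano in place of trifluoromethyl on an aromatic carbon. The two measured steps ending at compound 3 both weakened inhibition beyond the scatter, so a return toward the measured range is expected rather than a further loss. For compound 4 a step of an at least 2.0-fold lower number from compound 3 to compound 4 (0.30 log units; that floor lies within the scatter) in this assay is expected. The estimate for compound 4 in this assay is 50000 nM, ranging from 15000 nM to 200000 nM.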

Compound 4, half-maximal inhibitory concentration: 3810 nM
Compound 4: the middle estimate sits 13-fold (1.12 log units) above what was measured, outside the stated range (below it).
By their numbers in this assay, from the lowest: compound 4; then compound 1; then compound 2. At a limit, above all of these: compound 3.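

Cyano on this aromatic carbon gives a 3.6-fold lower number from compound 1 to compound 4 (0.55 log units; beyond the scatter) in this assay, so substitution here need not weaken inhibition, as phenyl and trifluoromethyl had. The same group also stands clear of phenyl, with a 9.0-fold lower number from compound 2 to compound 4 (0.95 log units; beyond the scatter), and of trifluoromethyl, with an at least 26-fold lower number from compound 3 to compound 4 (1.41 log units; beyond the scatter). That last step is only a floor, as compound 3 stands at a limit of the assay: the limit of > 100000 nM in this assay, at which 1 of the 4 values shown sits.

The compounds shown leave open whether the gain is particular to cyano or would also come with an amide, a carboxylic acid or a methoxy group at this place.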